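The compounds below may be only part of what the source reports. "The series", "measured", "known", "first", "only" and "open" are said of these compounds alone.

Among the measured compounds shown here, compound 3, with the structure `CCc1ccc(C(=O)Nc2cccc(NC(=O)COc3ccc4c(=O)ccoc4c3)c2)cc1`, gives 24 nM in an assay on isolated protein for inhibition of Rho-associated protein kinase 2 (Homo sapiens), read by scintillation counting, radiometric assay and 33P incorporation, with a stated time of 40 min, in the presence of a further agent that is not named here (a lower number here means a stronger inhibitor, a higher number a weaker inhibitor), the lowest of the three numbers so far. Compound 2, `COc1cc(OCC(=O)Nc2cccc(NC(=O)c3ccc(N(C)C)cc3)c2)ccc1C=O`, gives 306 nM, and compound 1, `CN(C)c1ccc(C(=O)Nc2cccc(NC(=O)COc3ccc4c(c3)NC(=O)CC4)c2)cc1`, gives 3140 nM. For the measured compounds named here, the only step between two compounds that differ in one place is a 10-fold lower number from compound 1 to compound 2 (1.01 log units; beyond the scatter), and that change sits on an oxygen on a saturated carbon, far from the end of the molecule that is altered here.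

Compound 4, with the structure `Nc1ccc(C(=O)Nc2cccc(NC(=O)COc3ccc4c(=O)ccoc4c3)c2)cc1`, differs from compound 3 as amino in place of ethyl on an aromatic carbon, on an aromatic carbon of a six-membered aromatic ring of carbon only. Going by the values given here, no measured step touches this part of the shared core, so nothing in the data shows how this assay answers to a change at that place; the step from compound 1 to compound 2 only shows that a change elsewhere can move the number far. With no guide, the expected step for compound 4 is a modest weakening, a 2.5-fold higher number from compound 3 to compound 4 (0.40 log units; beyond the scatter), with a wide band around it. Compound 4 is therefore estimated to give 60 nM in this assay, expected to lie between 15 nM and 250 nM.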

Compound 4, half-maximal inhibitory concentration: 83 nM
Estimate against measurement, compound 4: 1.4-fold (0.14 log units) below; the measured number falls inside the stated range.
By their numbers in this assay, from the lowest: compound 3; then compound 4; then compound 2; then compound 1.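

In this assay, among the compounds shown here, amino in place of ethyl on an aromatic carbon, para to a large group, gives a 3.5-fold higher number from compound 3 to compound 4 (0.54 log units; beyond the scatter) and so provides the first reading at this position, showing that the number responds to a change here as well as to the change on the oxygen on a saturated carbon. The exchange swaps ethyl, with two carbons and no hydrogen-bond donor or acceptor, for amino, with one nitrogen, one hydrogen-bond donor and one hydrogen-bond acceptor, and this one pair cannot show which of these differences matters for the step. Nothing measured on either group accounts for the difference between the two compounds.

The compounds shown leave open whether a methyl, a propyl or a longer chain at this position would keep the number near that of compound 3, and whether a hydroxyl, a methoxy or a carboxylic acid would move it in the way amino does. For the compounds shown here, they also leave open whether the same exchange would give a step of similar size on a different core, since it is seen here on only one pair.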